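Thiophenyl Replaces Cyclohexylmethyl on a Sulfonyl Sulfur

A few compounds are considered here, and "the series" means these few. Any claim that something is new, unique, unknown or untested is made for them only; others in the source may bear on it.

Among the compounds with values here, compound 2 `CC(C)OC(=O)N1CCC(COc2ccc(N3CCN(S(=O)(=O)CC4CCCCC4)CC3)nc2)CC1` is the only compound for which a number, rather than a limit, is known in a functional assay on CHO-K1 cells for agonist activity at Glucose-dependent insulinotropic receptor (Homo sapiens), read by a luciferase reporter, with a stated time of 5 h; on this read-out lower numbers stand for an effect already at smaller amounts and higher numbers for an effect only at larger amounts of compound; in this assay compound 2 gives 90 nM. Compound 1 `CC(C)OC(=O)N1CCC(COc2ccc(N3CCN(C(=O)N(C)C)CC3)nc2)CC1` shares the core and carries dimethylcarbamoyl on the ring amine nitrogen where compound 2 carries (cyclohexylmethyl)sulfonyl. In this assay compound 1 reaches only a limit, > 10000 nM. Within the data shown here, the single measured step is an at least 110-fold lower number from compound 1 to compound 2 (2.04 log units; beyond the scatter); its size is set by the limit of > 10000 nM in this assay, at which 1 of the 2 values shown sits, and so is a minimum. Compound 3 `CC(C)OC(=O)N1CCC(COc2ccc(N3CCN(S(=O)(=O)c4cccs4)CC3)nc2)CC1` is the compound not yet measured, and (thiophen-2-yl in place of cyclohexylmethyl on a sulfonyl sulfur). Among the measured compounds shown here, the sulfonyl and the ring sulfonamide nitrogen that distinguished compound 2 from compound 1 are kept, so the one measured step speaks for the sulfonyl itself, not for the group attached to its sulfur. For the measured compounds named here, with no step between two different groups on that sulfur, he expects a change of modest size in this assay, in either direction. Compound 3 is therefore estimated at 150 nM, between 30 nM and 800 nM, an expected step of a 1.7-fold higher number from compound 2 to compound 3 (0.22 log units; within the scatter).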

Compound 3, half-maximal effective concentration: 1800 nM
Compound 3: the middle estimate sits 12-fold (1.08 log units) below what was measured, outside the stated range (above it).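

In this assay, within the data shown here, the group on the sulfonyl sulfur counts for a great deal in its own right, which the earlier compounds could not show: a 20-fold higher number from compound 2 to compound 3 (1.30 log units; beyond the scatter). The sulfonyl alone therefore does not fix the level reached, and cyclohexylmethyl serves far better here than thiophen-2-yl. Yet the sulfonyl with thiophen-2-yl on its sulfur still keeps part of the advantage over dimethylcarbamoyl on the ring amine nitrogen, with an at least 5.5-fold lower number from compound 1 to compound 3 (0.74 log units; beyond the scatter), and this step is a minimum, set by a limit: the limit of > 10000 nM in this assay, at which 1 of the 3 values shown sits.

The change replaces a six-membered non-aromatic ring of carbon only with a five-membered aromatic ring with 1 hetero atom, and it also removes the methyl link of cyclohexylmethyl, so the compounds shown do not say which of these differences carries the step. As far as these compounds go, a cyclohexyl group set directly on the sulfur, a benzyl group or a thiophen-2-ylmethyl group would each separate these differences, and how such groups would behave on this sulfonyl sulfur remains open.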